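The source may report more compounds than this note shows. Statements on the series, on what has been measured and on what is new or still open speak of the compounds shown alone.

Measured compounds:
compound 1, `CC(C)(C)OC(=O)N1CCC(O[C@H]2CC[C@H](Oc3ccc(S(C)(=O)=O)cc3F)CC2)CC1`: in a functional assay on isolated protein for agonist activity at Glucose-dependent insulinotropic receptor (Homo sapiens), read by HTRF and cAMP accumulation (a lower number here means a smaller maximal response, a higher number a larger maximal response), compound 1 gives 113%
compound 2, `CC(C)OC(=O)N1CCC(O[C@H]2CC[C@H](Oc3cnc(S(C)(=O)=O)cn3)CC2)CC1`: in this assay compound 2 gives 110%

Working notes on the series. Both measured compounds reach a largest response at or above that of the reference in this assay. Among the compounds with values here, the value of compound 2 sits within the usual scatter of the value of compound 1, so the two cannot be told apart on these numbers; no step between them is drawn, and nothing beyond the scatter separates them.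

The next compound is compound 3, `CC(F)Cc1nc(CN2CCC(O[C@H]3CC[C@H](Oc4cnc(S(C)(=O)=O)cn4)CC3)CC2)no1`. Its change from compound 2 is (5-(2-fluoropropyl)-1,2,4-oxadiazol-3-yl)methyl in place of isopropoxycarbonyl on an amine nitrogen in a ring. Within the data shown here, no step between measured compounds shows what such a change at this position does to the largest response; the only guide is that the two measured compounds, which differ elsewhere, both reach a full response in this assay.

On that basis the largest response of compound 3 is expected to remain near the reference level, and the estimated step from compound 2 is a number 5 percentage points lower from compound 2 to compound 3 (within the scatter), which is not expected to exceed the scatter. The estimate for compound 3 in this assay is 105%, with a range from 85% to 125%.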

Compound 3, largest response reached (Emax), in percent of the reference or control that the assay uses: 97%
Estimate against measurement, compound 3: 8 percentage points above; low and high end bracket the measured number.
By their numbers in this assay, from the lowest: compound 3; then compounds 2 and 1 (each within the scatter of the next).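

In this assay, within the data shown here, (5-(2-fluoropropyl)-1,2,4-oxadiazol-3-yl)methyl in place of isopropoxycarbonyl on the amine nitrogen in the ring gives a number 13 percentage points lower from compound 2 to compound 3 (beyond the scatter), the first step that isolates this position. It shows that the largest response depends on the group at this nitrogen, although only modestly, and that compound 3 still reaches 97% with no isopropoxycarbonyl present, its place taken by a larger group with a five-membered aromatic ring. No measurement available here accounts for this step.

The single change replaces the whole group, so the compounds shown do not separate the contributions of the fluorine, the 2-fluoropropyl chain, the aromatic ring and the methyl that joins it to the nitrogen; an unfluorinated propyl chain on the same ring, or a plain benzyl group on the nitrogen, would bear on that question. Also open, going by these compounds, is whether the same change would give a step of similar size on the core of compound 1, and whether a tert-butoxycarbonyl group in place of isopropoxycarbonyl on the core of compound 2 would alter the response at all.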